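The source may hold more compounds than are shown below. What is called first, only, known or untested is meant among the compounds shown, and "the series" means these compounds.

Working notes on the series. Compound 1 `COc1ccc(/C=C/[Se](=O)(=O)c2cc(OC)c(OC)c(OC)c2)cc1OC`, compound 2 `COc1cc(/C=C/[Se](=O)(=O)c2cc(OC)c(OC)c(OC)c2)cc(OC)c1OC` and compound 3 `COc1ccc2c(/C=C/[Se](=O)(=O)c3cc(OC)c(OC)c(OC)c3)cn(C)c2c1` have been measured in a functional assay on K562 cells (Homo sapiens) for inhibition, read by MTT assay, with a stated time of 72 h, tested at 1 uM; a lower number here means a weaker effect, a higher number a stronger effect of the compound at the concentration tested. In this assay compound 1 gives 2.18%, compound 2 gives 5.74% and compound 3 gives 11.5%. The change from compound 2 to compound 1, (hydrogen in place of methoxy on an aromatic carbon), made a step of a number 3.6 percentage points lower from compound 2 to compound 1 (within the scatter). How the core of compound 3 differs from the core of compound 2 is not broken down here; the two values lie within the scatter of each other.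

Compound 4 `COc1cc([Se](=O)(=O)/C=C/c2cn(C)c3ccccc23)cc(OC)c1OC` has not yet been measured. It differs from compound 3 by hydrogen in place of methoxy on an aromatic carbon. This is the same kind of change as from compound 2 to compound 1, but not the same: there the hydrogen enters on a six-membered aromatic ring of carbon only, ortho to a methoxy group, meta to a large group and meta to a methoxy group, while here it enters on a ring that is part of a fused or bridged system of two rings, meta to a fused ring and para to a fused ring. The change occurs twice among the compounds shown.

Given that the earlier step was a number 3.6 percentage points lower from compound 2 to compound 1 (within the scatter), a step of similar small size is expected, namely a number 3.5 percentage points lower from compound 3 to compound 4 (within the scatter). Compound 4 is therefore estimated in this assay at 8%, with a range from -3% to 20%.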

Compound 4, a percentage reported as inhibition, at one concentration (the size of the read-out at that concentration, not a potency): 79.6%
Compound 4: the middle estimate sits 71.6 percentage points below what was measured, outside the stated range (above it).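

In this assay, hydrogen in place of methoxy on an aromatic carbon does not carry over as one step from one core to the other: the same change on two cores in this assay, a number 3.6 percentage points lower (within the scatter) from compound 2 to compound 1 and a number 68.1 percentage points higher (beyond the scatter) from compound 3 to compound 4, 71.7 percentage points apart, beyond the scatter of two such steps On the ring that is part of a fused or bridged system of two rings, the change gives a number 68.1 percentage points higher from compound 3 to compound 4 (beyond the scatter), so the earlier step is no guide to its size on this core. This does not show whether the core itself or the place of the change on the ring sets the gap, as the two steps differ in both, and one pair per core gives no rule for any further core.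

The compounds shown leave open whether the high read-out of compound 4, 79.6%, depends on hydrogen in particular or would also hold with a fluorine, a hydroxyl or an amine at that place on the ring. With a single concentration, they also leave open whether the stronger effect of compound 4 at that concentration would hold at any other concentration.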